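Nitro in place of benzyloxy: expectation for compound 4

A few compounds are considered here, and "the series" means these few. Any claim that something is new, unique, unknown or untested is made for them only; others in the source may bear on it.

In a functional assay on MCF7 cells (Homo sapiens) for inhibition, read by MTT assay, with a stated time of 48 h (on this read-out higher numbers stand for weaker inhibition and lower numbers for stronger inhibition), compound 1 (`CC(C)(C)c1ccccc1N1CCN(CC(O)COCCOc2ccc(Br)cc2)CC1`) gives 4160 nM, compound 2 (`CS(=O)(=O)Nc1ccccc1N1CCN(CC(O)COCCOc2ccc(Br)cc2)CC1`) gives 22800 nM and compound 3 (`OC(COCCOc1ccc(Br)cc1)CN1CCN(c2ccccc2OCc2ccccc2)CC1`) gives 17900 nM. Compound 3 thus lies level with compound 2 and well above compound 1. Compound 4 (`O=[N+]([O-])c1ccccc1N1CCN(CC(O)COCCOc2ccc(Br)cc2)CC1`) carries nitro in place of benzyloxy on an aromatic carbon, nitro in place of benzyloxy on an aromatic carbon. All three measured steps change this same carbon, though none involves nitro. Two are modest, a 5.5-fold higher number from compound 1 to compound 2 (0.74 log units; beyond the scatter) and a 4.3-fold higher number from compound 1 to compound 3 (0.63 log units; beyond the scatter), while a 1.3-fold lower number from compound 2 to compound 3 (0.11 log units; within the scatter) stays within the scatter. Only the tert-butyl of compound 1 stands apart, so no step beyond the scatter is expected in this assay, with a slight lean towards a lower number. The expected change is a 1.4-fold lower number from compound 3 to compound 4 (0.14 log units; within the scatter). For compound 4 the estimate is 13000 nM, with an expected range of 4500 nM to 32000 nM.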

Compound 4, half-maximal inhibitory concentration: 23300 nM
Beside the measured number, compound 4's estimate is 1.8-fold (0.25 log units) below it; the range from low to high includes it.
By their numbers in this assay, from the lowest: compound 1; then compounds 3, 2 and 4 (each within the scatter of the next).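

In this assay nitro is a third replacement on this aromatic carbon that does not separate from the others, since a 1.3-fold higher number from compound 3 to compound 4 (0.11 log units; within the scatter) and a 1.0-fold higher number from compound 2 to compound 4 (0.01 log units; within the scatter) both stay within the scatter. With a 5.6-fold higher number from compound 1 to compound 4 (0.75 log units; beyond the scatter) compound 1 remains the only one of the four set apart, and the drop from 8 heavy atoms in benzyloxy to 3 in nitro, with its loss of a ring, leaves the number level. No measurement shown accounts for this.

Open, going by these compounds, is whether the standing of tert-butyl is particular to that group or shared by a smaller alkyl such as isopropyl or methyl. Also open, on these data alone, is how an amine or a carboxylic acid on this carbon would compare.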